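The source may report more compounds than this note shows. Statements on the series, on what has been measured and on what is new or still open speak of the compounds shown alone.

Measured so far:
compound 1 `FC(F)(F)c1ccccc1Nc1nc2nonc2nc1Nc1ccccc1C(F)(F)F` gives 1000 nM
compound 2 `CCc1ccc(Nc2nc3nonc3nc2Nc2ccc(CC)cc2)cc1` gives 3900 nM
compound 3 `Fc1ccc(Nc2nc3nonc3nc2Nc2ccccc2F)cc1` gives 2300 nM

These three share a core and carry two substituted phenyl groups on the two nitrogens. In an assay on mitochondria from L6 cells (Rattus norvegicus) for activation, with a stated time of 90 min (a lower number here means that less compound is needed, a higher number that more compound is needed for the effect), compound 3 gives 2300 nM, the second highest of the three numbers. Its nearest neighbour is compound 2, whose value of 3900 nM lies within the usual scatter of that of compound 3, so the two cannot be told apart. Compound 1, with 1000 nM, has a number beyond the scatter below that of compound 3, and it is the only one of the three whose two phenyl groups both carry a substituent at position 2.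

Compound 4 `CCOc1ccccc1Nc1nc2nonc2nc1Nc1ccccc1F` has not been measured in this assay. It differs from compound 3 in one place: 2-ethoxyphenyl in place of 4-fluorophenyl on a nitrogen on an aromatic ring. Among the compounds with values here, no step between measured compounds isolates this change, so the expectation rests on the whole set. Because compound 1 gives 1000 nM with two 2-substituted phenyl groups, a step from compound 3 to compound 4 towards a lower number is expected, of a size that may not exceed the scatter, a 1.5-fold lower number from compound 3 to compound 4 (0.19 log units; within the scatter). Compound 4 is estimated at 1500 nM, with a range from 500 nM to 5000 nM.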

Compound 4, half-maximal effective concentration: 5600 nM
Compound 4: middle estimate off by 3.7-fold (0.57 log units), on the low side, and the stated range ends below it.
By their numbers in this assay, from the lowest: compound 1; then compounds 3, 2 and 4 (each within the scatter of the next, the first and the last beyond it).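

In this assay, within the data shown here, the step of a 2.4-fold higher number from compound 3 to compound 4 (0.39 log units; beyond the scatter) is the first direct reading at this place, and it shows that 2-ethoxyphenyl in place of 4-fluorophenyl on this nitrogen raises the number rather than lowering it. Compound 1 differs from compound 4 in more than one place, so its value gives no firm guide to this change, and the step shows that a 2-ethoxyphenyl group at this place does not by itself bring a lower number. The change alters both the substituent and where it sits on the phenyl ring, and the entering group also has more heavy atoms and brings a hydrogen-bond acceptor, but nothing measured here ties the step to any one of these differences.

The compounds shown leave open whether the higher number follows the ethoxy group itself or its place on the ring, a question that a 4-ethoxyphenyl group on the same nitrogen would address. They also leave open whether a shorter 2-methoxyphenyl group, or a 2-aminophenyl group, would move the number in the same direction.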